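A few compounds are considered here, and "the series" means these few. Any claim that something is new, unique, unknown or untested is made for them only; others in the source may bear on it.

Measured compounds:
compound 1, `CC(Sc1nc2nn(C3COC3)cc2c(=O)n1-c1ccccc1)c1ccccc1` — 65 nM
compound 2, `Cn1ncc2c(=O)n(-c3ccccc3)c(/C=C/c3cccc(F)c3)nc21` — 440 nM
compound 3, `CC(Sc1nc2nn(C3(C)COC3)cc2c(=O)n1-c1ccccc1)c1ccccc1` — 112 nM

These three compounds were tested in an assay on isolated protein for inhibition of retinal dehydrogenase 2 (Homo sapiens); a lower number here means a stronger inhibitor, a higher number a weaker inhibitor. Among the three numbers, compound 1 gives the lowest; its nearest neighbour is compound 3, and the step of a 1.7-fold higher number from compound 1 to compound 3 (0.24 log units; within the scatter) lies within the scatter. Compound 2 stands furthest away, and it differs from compound 1 in several places, so the two values alone show that compound 2 gives the higher number.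

The unmeasured compound 4, `CC(Sc1nc2nn(C3COC3)cc2c(=O)n1-c1ccccc1)c1ccccn1`, differs from compound 1 by one change: pyridin-2-yl in place of phenyl on a saturated chain carbon bound to a saturated chain carbon and a sulfur. Among the compounds with values here, no measured step touches this change. Within the data shown here, the only step recorded, from compound 1 to compound 3, concerns a methyl on a saturated ring carbon and is within the scatter, so it offers no guide for a shift from phenyl to pyridin-2-yl. With nothing directly comparable, the expectation for compound 4 in this assay is a step of a 1.4-fold higher number from compound 1 to compound 4 (0.14 log units; within the scatter), that is, no change beyond the scatter, with a wide range to cover the uncertainty. Compound 4 is therefore estimated at 90 nM, between 30 nM and 270 nM.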

Compound 4, half-maximal inhibitory concentration: 21 nM
The estimate for compound 4 lay 4.3-fold (0.63 log units) above the measured number; measured number below the stated range.
By their numbers in this assay, from the lowest: compound 4; then compounds 1 and 3 (each within the scatter of the next); then compound 2.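

In this assay, the exchange of phenyl for pyridin-2-yl on the saturated chain carbon gives a 3.1-fold lower number from compound 1 to compound 4 (0.49 log units; beyond the scatter), so this position responds to a change within the aromatic ring itself. Both groups have 6 heavy atoms and a six-membered aromatic ring, but pyridin-2-yl has 1 nitrogen in that ring and 1 hydrogen-bond acceptor, so a small exchange of atoms is enough to move the number beyond the scatter. Nothing available here accounts for the shift.

The compounds shown leave open whether pyridin-3-yl, pyridin-4-yl or pyrimidin-2-yl at the same place would give a similar number. They also leave open whether the same exchange would lower the number for compound 3, which carries the extra methyl on a saturated ring carbon.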